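This account rests on a few compounds, and the source may have more. Where it says the series, first, only, none or still open, it means among the compounds named here.

Measured compounds in a functional assay on B16-F10 cells (Mus musculus) for inhibition, read by MTT assay, with a stated time of 72 h; a lower number here means a stronger inhibitor, a higher number a weaker inhibitor:
- compound 1 `CC(C)c1ccc(-c2nc(SCc3cn(CC(=O)NC(=O)Nc4ccccn4)nn3)nc(Nc3ccc(F)cc3)c2C#N)cc1` gives 7250 nM
- compound 2 `CC(C)c1ccc(-c2nc(SCc3cn(CC(=O)NC(=O)Nc4ccccn4)nn3)nc(Nc3ccccc3)c2C#N)cc1` gives 14300 nM
- compound 3 `Cc1cccc(Nc2nc(SCc3cn(CC(=O)NC(=O)Nc4ccccn4)nn3)nc(-c3ccc(C(C)C)cc3)c2C#N)c1` gives 1650 nM

Compound 3 stands lowest of the three numbers in this assay, and both of its steps to the others lie beyond the scatter: a 4.4-fold lower number from compound 1 to compound 3 (0.64 log units; beyond the scatter) and an 8.7-fold lower number from compound 2 to compound 3 (0.94 log units; beyond the scatter). The remaining pair, a 2.0-fold higher number from compound 1 to compound 2 (0.29 log units; within the scatter), lies within the scatter.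

Compound 4 `COc1ccccc1Nc1nc(SCc2cn(CC(=O)NC(=O)Nc3ccccn3)nn2)nc(-c2ccc(C(C)C)cc2)c1C#N` differs from compound 3 only in the aryl group on the same nitrogen: 2-methoxyphenyl in place of 3-methylphenyl on a nitrogen on an aromatic ring. Going by the values given here, the steps that bear on this are the two that also change the group on that nitrogen, from compound 1 and from compound 2 to compound 3; both are modest and both point toward compound 3 as the lowest number. Among the compounds with values here, neither involves a methoxy group or a group placed as in 2-methoxyphenyl, so the direction for compound 4 rests on no direct precedent. Because compound 3 gives 1650 nM and is the lowest point seen, and because the steps of a 4.4-fold lower number from compound 1 to compound 3 (0.64 log units; beyond the scatter) and an 8.7-fold lower number from compound 2 to compound 3 (0.94 log units; beyond the scatter) are each modest, a modest rise back toward compound 1 is the expected step, a 2.1-fold higher number from compound 3 to compound 4 (0.33 log units; beyond the scatter), with the possibility of no change beyond the scatter. Compound 4 is thus estimated at 3500 nM in this assay, within the range 1200 nM to 10000 nM.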

Compound 4, half-maximal inhibitory concentration: 34600 nM
Compound 4: middle estimate off by 9.9-fold (1.00 log units), on the low side; measured number outside the range, above it.
By their numbers in this assay, from the lowest: compound 3; then compounds 1 and 2 (each within the scatter of the next); then compound 4.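

In this assay, the aryl group on this nitrogen can move the number upward as well as downward: the change to 2-methoxyphenyl gives a 21-fold higher number from compound 3 to compound 4 (1.32 log units; beyond the scatter), the largest step in the series, and leaves compound 4 the weakest of the four. Substitution on this aryl ring therefore has no single direction, since methyl in place of hydrogen gives an 8.7-fold lower number from compound 2 to compound 3 (0.94 log units; beyond the scatter), whereas methoxy in place of hydrogen gives a 2.4-fold higher number from compound 2 to compound 4 (0.38 log units; beyond the scatter); the change from 4-fluorophenyl to 2-methoxyphenyl likewise gives a 4.8-fold higher number from compound 1 to compound 4 (0.68 log units; beyond the scatter). No supporting measurement is available to account for these differences.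

Open, as far as these compounds go, is whether the rise follows the methoxy group itself or its placement on the ring, and a 3-methoxyphenyl or a 2-methylphenyl on the same nitrogen would separate the two. Also open, from the compounds shown here alone, is how far the low number of compound 3 extends to other groups on this ring, such as 3-ethylphenyl or a 3-aminophenyl bearing an amine.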